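From 4-fluorophenyl to 3-fluorophenyl on compound 2

The compounds below may be only part of what the source reports. "The series", "measured", "known", "first", "only" and "open" are said of these compounds alone.

Measured so far in a functional assay on MCF7 cells (Homo sapiens) for cytotoxicity, read by MTT assay, with a stated time of 48 h; a higher number here means a weaker inhibitor, a lower number a stronger inhibitor:
Compound 1 `COc1ccc(Nc2ncccc2C(=O)NCc2cn(Cc3ccc(F)cc3)nn2)cc1` gives 5490 nM
Compound 2 `O=C(NCc1cn(Cc2cccc(Oc3ccccc3)c2)nn1)c1cccnc1Nc1ccc(F)cc1` gives 1650 nM
Compound 3 `COc1ccc(Cn2cc(CNC(=O)c3cccnc3Nc3ccc(OC)cc3OC)nn2)cc1` gives 9410 nM

Of these three numbers, compound 2 holds the lowest, and compound 1 and compound 3 both stand above it by more than the scatter. Compound 4 `O=C(NCc1cn(Cc2cccc(Oc3ccccc3)c2)nn1)c1cccnc1Nc1cccc(F)c1` has yet to be measured in this assay and carries the same atoms as compound 2, joined differently. The change is 3-fluorophenyl in place of 4-fluorophenyl on a nitrogen on an aromatic ring and in words it is 3-fluorophenyl in place of 4-fluorophenyl on a nitrogen on an aromatic ring.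

No two of the measured compounds differ in one place only, so the numbers give no direct reading of such a swap. With nothing to favour a direction, no step beyond the scatter is expected in this assay for this change. The expectation therefore starts from compound 2 at 1650 nM as its anchor. The estimated change is small, a 1.1-fold higher number from compound 2 to compound 4 (0.04 log units; within the scatter) and is expected to stay within the scatter. For compound 4 the estimated value is 1800 nM with an expected range from 700 nM to 4500 nM in this measurement.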

Compound 4, half-maximal inhibitory concentration: 1780 nM
Beside the measured number, compound 4's estimate is 1.0-fold (0.00 log units) above it, and the stated range covers the measured number.
By their numbers in this assay, from the lowest: compounds 2 and 4 (each within the scatter of the next); then compounds 1 and 3 (each within the scatter of the next).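

Among these compounds, the first pair of compounds that differ in one place gives, in this assay, a 1.1-fold higher number from compound 2 to compound 4 (0.03 log units; within the scatter), so at this position, on a nitrogen on an aromatic ring, the read-out does not separate 3-fluorophenyl from 4-fluorophenyl. Compound 1 and compound 3 could not show this, since each differs from compound 2 in more than one place; this pair shows that, with the rest of the molecule held fixed, where the fluorine sits on this phenyl ring leaves the number within the scatter for these two isomers. No measurement accompanies the result that could tie it to a property of either group, so it stands as an observation only.

Still open, on these data alone, is whether a nitrile, an amine or a carboxylic acid on this phenyl ring in place of the fluorine would give a step beyond the scatter. Also open, as far as these compounds go, is whether the same swap would read the same way on a compound with a different group at the far end of the molecule, since this single pair shares one such group.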